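Swapping an aryl group on an imidazopyrazine core

The source may hold more compounds than are shown below. What is called first, only, known or untested is meant among the compounds shown, and "the series" means these compounds.

Measured compounds in a functional assay on MOLT-4 cells (Homo sapiens) for inhibition, read by sulforhodamine B assay, with a stated time of 48 h, tested at 10 uM; on this read-out lower numbers stand for less inhibition and higher numbers for more inhibition at the one concentration tested (going by the name of the read-out):
compound 1 `Brc1cn2ccnc2c(-c2ccc3ncn(C4CCCCC4)c3c2)n1` gives 26.3%;
compound 2 `O=Cc1ccc(-c2cn3ccnc3c(-c3ccc4ncn(C5CCCCC5)c4c3)n2)cc1` gives 58.7%;
compound 3 `c1ccc2c(-c3cn4ccnc4c(-c4ccc5ncn(C6CCCCC6)c5c4)n3)cccc2c1` gives 44.7%.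

Compound 3 sits second of the three numbers in this assay: compound 2 lies above it, with a number 14 percentage points lower from compound 2 to compound 3 (beyond the scatter), and compound 1 lies below it, with a number 18.4 percentage points higher from compound 1 to compound 3 (beyond the scatter).

Compound 4 `CC(=O)c1ccc(-c2cn3ccnc3c(-c3ccc4ncn(C5CCCCC5)c4c3)n2)cc1` differs from compound 3 in one place: 4-acetylphenyl in place of naphthalen-1-yl on an aromatic carbon

Within the data shown here, the step that bears on this is the one between compound 2 and compound 3, since 4-acetylphenyl closely resembles 4-formylphenyl, which gave a number 14 percentage points lower from compound 2 to compound 3 (beyond the scatter). Reversing that change is therefore expected to raise inhibition by a modest amount, a number 10.3 percentage points higher from compound 3 to compound 4 (beyond the scatter). Compound 4 is expected to give 55%, within 40% to 70%.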

Compound 4, a percentage reported as inhibition, at one concentration (the size of the read-out at that concentration, not a potency): 14.3%
The estimate for compound 4 lay 40.7 percentage points above the measured number; measured number below the stated range.
By their numbers in this assay, from the lowest: compound 4; then compound 1; then compound 3; then compound 2.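

The effect at this position depends on small details: methyl in place of hydrogen on the carbonyl carbon gives a number 44.4 percentage points lower from compound 2 to compound 4 (beyond the scatter) and so separates 4-acetylphenyl sharply from 4-formylphenyl. An aryl group here does not always beat bromo, as 4-acetylphenyl shows with a number 12 percentage points lower from compound 1 to compound 4 (beyond the scatter) even though compound 2 and compound 3 exceed compound 1, and it also trails naphthalen-1-yl, with a number 30.4 percentage points lower from compound 3 to compound 4 (beyond the scatter) in the same direction. No measured evidence accounts for this drop. On these data alone, how an amine or a carboxylic acid on the same phenyl ring would read remains open.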